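The source may hold more compounds than are shown below. What is called first, only, known or untested is meant among the compounds shown, and "the series" means these compounds.

Measured in a functional assay on MCF7 cells (Homo sapiens) for cytotoxicity, read by MTT assay, with a stated time of 48 h (a lower number here means a stronger inhibitor, a higher number a weaker inhibitor), so far:
compound 1 `CC(C)=CCC/C(C)=C/CC/C(C)=C/CSc1ccccc1C(=O)N[C@@H](C)C(=O)OCCCCOc1no[n+]([O-])c1S(=O)(=O)c1ccccc1` gives 8680 nM;
compound 2 `CC(C)=CCC/C(C)=C/CC/C(C)=C/CSc1ccccc1C(=O)N[C@@H](C)C(=O)OCCOCCOc1no[n+]([O-])c1S(=O)(=O)c1ccccc1` gives 7680 nM;
compound 3 `CC(C)=CCC/C(C)=C/CC/C(C)=C/CSc1ccccc1C(=O)NCC(=O)OCCCCOc1no[n+]([O-])c1S(=O)(=O)c1ccccc1` gives 25100 nM.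

Compound 4 `CC(C)=CCC/C(C)=C/CC/C(C)=C/CSc1ccccc1C(=O)NCC(=O)OCCOCCOc1no[n+]([O-])c1S(=O)(=O)c1ccccc1` has not yet been measured. Compound 3 arises from compound 1 by a single change, (hydrogen in place of methyl on a saturated chain carbon bound to an amide-type nitrogen and a carbonyl carbon), and that change gave a 2.9-fold higher number from compound 1 to compound 3 (0.46 log units; beyond the scatter). Compound 4 arises from compound 2 by the same change, (hydrogen in place of methyl on a saturated chain carbon bound to an amide-type nitrogen and a carbonyl carbon), at a place described in the same words. How the core of compound 2 differs from the core of compound 1 is not broken down here; the two values in this assay lie within the scatter of each other. Because the earlier step was a 2.9-fold higher number from compound 1 to compound 3 (0.46 log units; beyond the scatter), a similar step is expected here, namely a 2.9-fold higher number from compound 2 to compound 4 (0.46 log units; beyond the scatter). Compound 4 is therefore estimated at about 22000 nM in this assay, most likely between 12000 nM and 40000 nM.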

Compound 4, half-maximal inhibitory concentration: 6590 nM
Compound 4: the middle estimate sits 3.3-fold (0.52 log units) above what was measured; measured number outside the range, below it.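

In this assay, putting hydrogen in place of methyl gives a 1.2-fold lower number from compound 2 to compound 4 (0.07 log units; within the scatter), so on this core the change leaves no difference beyond the scatter, unlike on the core of compound 1. The size of the step therefore did not carry over from one core to the other, as the two steps side by side show: the same change on two cores in this assay, a 2.9-fold higher number (0.46 log units; beyond the scatter) from compound 1 to compound 3 and a 1.2-fold lower number (0.07 log units; within the scatter) from compound 2 to compound 4, 3.4-fold (0.53 log units) apart, beyond the scatter of two such steps. With a single pair on each core, this does not show why the steps part, nor what the change would do on any further core.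

On these data alone, it stays open whether an ethyl group on the same saturated chain carbon would behave as on the core of compound 1 or as on the core of compound 2.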